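A few compounds are considered here, and "the series" means these few. Any claim that something is new, unique, unknown or untested is made for them only; others in the source may bear on it.

Of the compounds shown here, two so far have a number in a physicochemical assay for lipophilicity, read by LC-MS, using the shake flask method, in phosphate buffer, with a stated time of 50 min, at pH 7.4; a higher number here means a more lipophilic compound, a lower number a more polar compound. Compound 1 `CCCC(=O)NCCCCCC(=O)N[C@H](C(=O)N1C[C@H](O)C[C@H]1C(=O)NCc1ccc(-c2scnc2C)cc1)C(C)(C)C` gives 2.2, and compound 2 `CCCCOc1ccc(-c2ccc(C(=O)NCCCCCC(=O)N[C@H](C(=O)N3C[C@H](O)C[C@H]3C(=O)NCc3ccc(-c4scnc4C)cc3)C(C)(C)C)cc2)cc1` gives 1. Compound 1 is thus the higher of the two, and the gap between them lies beyond the usual scatter of repeated measurements. These two compounds differ by more than one simple swap, so their gap cannot be read as the effect of any single change.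

Compound 3 `COCC(=O)OCCCCCC(=O)N[C@H](C(=O)N1C[C@H](O)C[C@H]1C(=O)NCc1ccc(-c2scnc2C)cc1)C(C)(C)C` has not yet been measured in this assay. It keeps the core of compound 1 and departs from it in one place, on a saturated chain carbon, five bonds along the chain from a carbonyl carbon: ((methoxymethyl)carbonyl)oxy in place of (propylcarbonyl)amino on a saturated chain carbon, five bonds along the chain from a carbonyl carbon. Going by the values given here, no measured pair shows this swap, so the expectation rests on the structural change alone and stays uncertain. No step beyond the scatter is expected, in either direction. The estimated step of a number 0.10 log units lower from compound 1 to compound 3 (within the scatter) is correspondingly small. For compound 3 the estimated value is 2.1, with an expected range from 1.6 to 2.6.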

Compound 3, distribution coefficient: 1.7
Estimate against measurement, compound 3: 0.40 log units above, within the range that was stated.
By their numbers in this assay, from the lowest: compound 2; then compound 3; then compound 1.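

In this assay, putting ((methoxymethyl)carbonyl)oxy in place of (propylcarbonyl)amino on a saturated chain carbon, five bonds along the chain from a carbonyl carbon, gives a number 0.50 log units lower from compound 1 to compound 3 (beyond the scatter), so the number does respond to what sits at this place on the chain. The group that leaves and the group that enters both have 6 heavy atoms, no ring and no net charge, so the step appears with no change in these counts; what differs is the make-up, with 1 hydrogen-bond donor and 1 hydrogen-bond acceptor leaving, and 0 hydrogen-bond donors and 3 hydrogen-bond acceptors entering. No measurement available here accounts for the step.

This swap alters both the amino or oxy part and the propyl or methoxymethyl part at once, so the compounds shown leave open which of the two carries the step. A ((methoxymethyl)carbonyl)amino group or a (propylcarbonyl)oxy group at the same place would separate the two parts, and an amine or a carboxylic acid there would show how a different kind of group reads in this assay.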